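Stretching the Methoxy Group on Compound 1

The compounds below may be only part of what the source reports. "The series", "measured", "known", "first", "only" and "open" are said of these compounds alone.

Compound 1 `COc1cncc(C2=CC3CC(C2)CN(C)C3)c1` is the anchor of this small set. In an in vitro assay on SH-EP1 cells for displacement of a labelled ligand from Neuronal acetylcholine receptor; alpha4/beta2 (Homo sapiens) (on this read-out higher numbers stand for weaker inhibition and lower numbers for stronger inhibition), compound 1 gives 0.6 nM. Two measured neighbours frame it. Compound 2 `COc1cc(C2=CC3CC(C2)CN(C)C3)cnc1Cl`, which carries a chloro in place of hydrogen on an aromatic carbon, gives 4.4 nM in this assay, and the step of a 7.3-fold higher number from compound 1 to compound 2 (0.87 log units; beyond the scatter). Compound 3 `COc1cncc(C2=CC3CNCC(C2)C3)c1`, with hydrogen in place of methyl on an amine nitrogen in a ring, gives 0.3 nM, and the step of a 2.0-fold lower number from compound 1 to compound 3 (0.30 log units; within the scatter). So compound 1 sits second highest of the three numbers, close to compound 3 and clearly lower than compound 2.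

Compound 4 `CC(C)Oc1cncc(C2=CC3CC(C2)CN(C)C3)c1` has not yet been measured. It differs from compound 1 by isopropyl in place of methyl on an oxygen on an aromatic ring. Among the compounds with values here, neither measured step touches this oxygen: one alters an aromatic carbon, the other the ring amine, so no direct precedent exists. Within the data shown here, the one change made on the aromatic part, from compound 1 to compound 2, did weaken binding beyond the scatter, while the change on the amine did not. A larger group on the oxygen is therefore expected to cost some binding, though its size is uncertain. The estimated step is a 5.0-fold higher number from compound 1 to compound 4 (0.70 log units; beyond the scatter). Compound 4 is expected to give about 3 nM, within a range from 0.6 nM to 15 nM in this assay.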

Compound 4, inhibition constant: 2.2 nM
Compound 4: the middle estimate sits 1.4-fold (0.13 log units) above what was measured, within the range that was stated.
By their numbers in this assay, from the lowest: compounds 3 and 1 (each within the scatter of the next); then compounds 4 and 2 (each within the scatter of the next).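

This is the only change shown at the oxygen on the aromatic ring, and in this assay replacing methoxy with isopropoxy gives a 3.7-fold higher number from compound 1 to compound 4 (0.56 log units; beyond the scatter), so what this oxygen carries does matter for binding, even though the swap only takes a methyl of one carbon to an isopropyl of three. The loss is modest, and compound 4 still gives 2.2 nM, which means that the larger isopropyl group does not abolish binding at this position. Nothing measured here explains why the number rises, so this step records an effect without revealing its cause.

With only methyl and isopropyl shown on this oxygen, one step cannot reveal how binding changes across other groups, such as an ethyl, a straight propyl chain or a cyclopropyl ring, or whether a hydroxyl in place of the methoxy would be tolerated. From the compounds shown here alone, it also remains open whether isopropyl would produce a similar step on the core of compound 3, which has hydrogen rather than methyl on the ring amine.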